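A step from chloro to hydrogen at the assay limit

The compounds below may be only part of what the source reports. "The series", "measured", "known", "first", "only" and "open" are said of these compounds alone.

Of the compounds shown here, three have been read in a functional assay on OVCAR-3 cells (Homo sapiens) for cytotoxicity, read by MTT assay, with a stated time of 6 days (a higher number here means a weaker inhibitor, a lower number a stronger inhibitor), so far, and none has given a number. Compound 1 (`COc1ccccc1NC(=O)SC[C@H](NC(C)=O)C(=O)O`) gives > 200000 nM as a limit of the assay, not a measured value. Compound 2 (`CC(=O)N[C@@H](CSC(=O)Nc1ccccc1F)C(=O)O`) gives > 200000 nM as a limit too. Compound 3 (`CC(=O)N[C@@H](CSC(=O)Nc1cccc(Cl)c1)C(=O)O`) gives > 200000 nM as a limit as well, so it stands exactly where the other two stand.

In compound 4 (`CC(=O)N[C@@H](CSC(=O)Nc1ccccc1)C(=O)O`) hydrogen takes the place of the chloro of compound 3 on an aromatic carbon, meta to a large group; the counted change is hydrogen in place of chloro on an aromatic carbon and nothing else differs. Within the data shown here, the one measured step that bears on this is a step that the two limits leave unreadable from compound 1 to compound 2 and it is also a single exchange on an aromatic carbon, but it has no readable size. Among the measured compounds shown here, no measured step therefore points to a gain or a loss. A step beyond the scatter is not expected, because the limit of > 200000 nM in this assay, at which 3 of the 3 values shown sit, applies to compound 3 and to both other compounds. The expected outcome is a number no higher from compound 3 to compound 4 (the limit leaves the size open) and a report as a limit is the likeliest form it will take. For compound 4 the estimated value is 200000 nM with an expected range from 100000 nM to 400000 nM in this measurement.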

Compound 4, half-maximal inhibitory concentration: 153000 nM
Compound 4: the middle estimate sits 1.3-fold (0.12 log units) above what was measured; measured number inside the range.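

In this assay, among these compounds, compound 4 gives 153000 nM, the first value in this set that is a number and not a limit, so hydrogen in place of chloro on an aromatic carbon, meta to a large group, is the first change here with a readable direction: it gives an at least 1.3-fold lower number from compound 3 to compound 4 (0.11 log units; that floor lies within the scatter). The two other exchanges on the aromatic ring read the same way, with hydrogen in place of fluoro giving an at least 1.3-fold lower number from compound 2 to compound 4 (0.11 log units; that floor lies within the scatter) and hydrogen in place of methoxy giving an at least 1.3-fold lower number from compound 1 to compound 4 (0.11 log units; that floor lies within the scatter). Each of these steps is only a floor and not a size, because the other three compounds all stop at the same limit: the limit of > 200000 nM in this assay, at which 3 of the 4 values shown sit.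

The steps among compound 1, compound 2 and compound 3 cannot be read, so the compounds shown do not rank methoxy, fluoro and chloro against one another, and how far each lies from hydrogen remains open. Also open, from the compounds shown here alone, is whether an amine, a nitrile or a longer chain on this aromatic carbon would give a number that differs from that of compound 4 by more than the scatter.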